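Double-bond configuration step from compound 3 to compound 4

The source may hold more compounds than are shown below. What is called first, only, known or untested is meant among the compounds shown, and "the series" means these compounds.

Measured values in a functional assay on U-87MG ATCC cells (Homo sapiens) for cytotoxicity, read by MTT assay, with a stated time of 48 h (on this read-out higher numbers stand for weaker inhibition and lower numbers for stronger inhibition), for the series:
compound 1 `C/C(=N\NC(=S)Nc1ccc(Cl)cc1)c1ccccn1`: 1.7 nM
compound 2 `C/C(=N/NC(=S)Nc1ccc(Cl)cc1)c1ccccn1`: 1.7 nM
compound 3 `C/C(=N\NC(=S)Nc1ccc(F)cc1)c1ccccn1`: 10 nM

Compound 3 at 10 nM carries the highest number of the three. The change of fluoro in place of chloro gives a 5.9-fold higher number from compound 1 to compound 3 (0.77 log units; beyond the scatter) and sets the fluoro level apart from the chloro pair. Compound 4 `C/C(=N/NC(=S)Nc1ccc(F)cc1)c1ccccn1` is not yet measured. Against compound 3 the change is the two compounds have the same atoms and bonds and differ only in configuration as drawn: 1 of 1 stereo elements differ; a double bond is drawn E in compound 3 and Z in compound 4 and nothing else. Within the data shown here, the chloro pair offers the one measured step of this kind: no change at the digits printed from compound 1 to compound 2 (within the scatter) with the fact that compounds 1 and 2 differ only in the configuration as drawn as its whole structural basis. The fluoro step bears on the level expected for compound 4 and not on the configuration change itself. A single pair is thin support, but no step beyond the scatter is expected in this assay and the estimated size of no change at the digits printed from compound 3 to compound 4 (within the scatter) stays small in either direction. The estimate for compound 4 is 10 nM in this assay with an expected range from 5 nM to 20 nM as its bounds.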

Compound 4, half-maximal inhibitory concentration: 10 nM
For compound 4 middle estimate and measured number coincide at the digits printed, within the range that was stated.
By their numbers in this assay, from the lowest: compounds 1 and 2 (each within the scatter of the next); then compounds 3 and 4 (each within the scatter of the next).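

In this assay, the double-bond configuration now has a second measured pair, with no change at the digits printed from compound 3 to compound 4 (within the scatter), and the result seen for the chloro pair also holds for the fluoro pair. Fluoro in place of chloro on an aromatic carbon, earlier read only between the compounds drawn E, now also has a reading between the compounds drawn Z, with a 5.9-fold higher number from compound 2 to compound 4 (0.77 log units; beyond the scatter). The two readings agree: the same change on two cores in this assay, a 5.9-fold higher number (0.77 log units; beyond the scatter) from compound 1 to compound 3 and a 5.9-fold higher number (0.77 log units; beyond the scatter) from compound 2 to compound 4, 1.0-fold (0.00 log units) apart, within the scatter of two such steps

The compounds shown leave open how values in this assay respond to other groups on that aromatic carbon, such as bromo, a nitrile or an amine. From the compounds shown here alone, the configuration comparison covers only the chloro and fluoro pairs, and whether it holds with a longer chain in place of the methyl group on the double bond remains open.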